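The source may report more compounds than this note shows. Statements on the series, on what has been measured and on what is new or still open speak of the compounds shown alone.

Compound 1 `COc1cccc(-c2cc(C(=O)Nc3ccc(Oc4ccnc5cc(OCCCN6CCCCC6)c(OC)cc45)c(F)c3)c3ccccc3n2)c1`: 210 nM
Compound 2 `COc1cc2c(Oc3ccc(NC(=O)c4cc(-c5cccc(Cl)c5)nc5ccccc45)cc3F)ccnc2cc1OCCCN1CCCCC1`: 11 nM
Compound 3 `COc1cc2c(Oc3ccc(NC(=O)c4cc(-c5cccc(Cl)c5)nc5ccc(F)cc45)cc3F)ccnc2cc1OCCCN1CCC(C)CC1`: 60 nM

All three were tested in a functional assay on NCI-H460 cells (Homo sapiens) for cytotoxicity, read by MTT assay, with a stated time of 72 h; on this read-out lower numbers stand for stronger inhibition and higher numbers for weaker inhibition. Compound 2 and compound 1 differ in a single place: methoxy in place of chloro on an aromatic carbon. That one change produced a 19-fold higher number from compound 2 to compound 1 (1.28 log units; beyond the scatter), so within this pair the chloro compound stands well ahead of its methoxy counterpart.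

Compound 3 keeps the chloro group of compound 2, but the two differ in more than one place elsewhere; the difference between the two cores is not broken down here. In this assay compound 3 gives 60 nM, a weaker result than compound 2 and a stronger one than compound 1, and both of those gaps lie beyond the usual scatter.

Compound 4 `COc1cccc(-c2cc(C(=O)Nc3ccc(Oc4ccnc5cc(OCCCN6CCC(C)CC6)c(OC)cc45)c(F)c3)c3cc(F)ccc3n2)c1` has not yet been measured. Among the measured compounds shown here, it differs from compound 3 by methoxy in place of chloro on an aromatic carbon, which is the same change as the one separating compound 2 from compound 1, at the same place described in the same words. Because the same change gave a 19-fold higher number from compound 2 to compound 1 (1.28 log units; beyond the scatter), the expected step is a 15-fold higher number from compound 3 to compound 4 (1.18 log units; beyond the scatter). The expectation rests on a single measured pair, and the core of compound 3 is not that of compound 2, so the range is kept wide. Compound 4 is therefore estimated at 900 nM, with a range from 300 nM to 2700 nM.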

Compound 4, half-maximal inhibitory concentration: 840 nM
The estimate for compound 4 lay 1.1-fold (0.03 log units) above the measured number; the measured number falls inside the stated range.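

In this assay, going from 3-chlorophenyl to 3-methoxyphenyl on the core of compound 3 gave a 14-fold higher number from compound 3 to compound 4 (1.15 log units; beyond the scatter) and, set beside the earlier pair, the two steps do not differ: the same change on two cores in this assay, a 19-fold higher number (1.28 log units; beyond the scatter) from compound 2 to compound 1 and a 14-fold higher number (1.15 log units; beyond the scatter) from compound 3 to compound 4, 1.4-fold (0.13 log units) apart, within the scatter of two such steps. On these two cores, then, the change carries over at about the same size, and in both pairs the chloro compound stands well ahead of its methoxy counterpart. Among the compounds shown here, this is still only two pairs in a single cell assay, so it does not show that the step would keep its size on a third core, and it does not explain why methoxy costs so much here.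

From the compounds shown here alone, only chloro and methoxy appear at this place on the ring, so it remains open how a fluoro group, a trifluoromethyl group, a hydroxyl group or an amine would compare with them there. Going by these compounds, it also remains open whether the same step would hold on a compound with a longer chain in place of the side chain shared by these compounds.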